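Moving the Chlorine on the Urea Aryl Ring

This account rests on a few compounds, and the source may have more. Where it says the series, first, only, none or still open, it means among the compounds named here.

Compound 1 `O=C(Nc1cccc(CNc2nccnc2Cl)c1)Nc1ccccc1Cl` is the reference point of this small series. In a functional assay on HepG2 cells (Homo sapiens) for antiproliferative activity, read by MTT assay, with a stated time of 48 h (on this read-out higher numbers stand for weaker inhibition and lower numbers for stronger inhibition), compound 1 gives 8560 nM, which is the highest of the two plain numbers recorded, with compound 3 `O=C(Nc1cccc(CNc2nccnc2Cl)c1)Nc1ccc(Cl)cc1Br` close by at 6720 nM. Compound 2 `O=C(Nc1cccc(CNc2nccnc2Cl)c1)NC1CCCCC1` gives only a limit in this assay, > 40000 nM. The move to compound 4 `O=C(Nc1ccc(Cl)cc1)Nc1cccc(CNc2nccnc2Cl)c1` is described by 4-chlorophenyl in place of 2-chlorophenyl on an amide-type nitrogen. Within the data shown here, two measured steps bear on it. Exchanging one chlorinated aryl for another, a 1.3-fold lower number from compound 1 to compound 3 (0.11 log units; within the scatter), lies within the scatter. Among the measured compounds shown here, replacing the aryl with cyclohexyl, an at least 4.6-fold higher number from compound 1 to compound 2 (0.66 log units; beyond the scatter), is the only step that moves beyond the scatter, and it is known only as a limit (the limit of > 40000 nM in this assay, at which 1 of the 3 values shown sits). Since compound 4 keeps an aryl group and only relocates its chlorine, a step of the first kind is expected, not the second. Compound 4 is therefore expected to sit near its parent, a 1.0-fold lower number from compound 1 to compound 4 (0.00 log units; within the scatter), with an estimated value of 8500 nM, ranging from 3000 nM to 25000 nM.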

Compound 4, half-maximal inhibitory concentration: 8350 nM
Compound 4: the middle estimate sits 1.0-fold (0.01 log units) above what was measured, within the range that was stated.
By their numbers in this assay, from the lowest: compounds 3, 4 and 1 (each within the scatter of the next). At a limit, above all of these: compound 2.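

In this assay, exchanging 2-chlorophenyl for 4-chlorophenyl on the amide-type nitrogen leaves no readable difference, with a 1.0-fold lower number from compound 1 to compound 4 (0.01 log units; within the scatter), so the place of the chlorine does not separate these two compounds. Hydrogen in place of bromo also stays inside the scatter, with a 1.2-fold higher number from compound 3 to compound 4 (0.09 log units; within the scatter), which shows that the bromo is not needed to hold this level. The gap to cyclohexyl now appears with a second chlorophenyl group, with an at least 4.7-fold lower number from compound 2 to compound 4 (0.68 log units; beyond the scatter), though its size rests on a limit for compound 2: the limit of > 40000 nM in this assay, at which 1 of the 4 values shown sits.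

The compounds shown leave open whether a plain phenyl, or a methoxy group or carboxylic acid on the aryl ring, would stay at this level. They also leave open what an amine in place of the chlorine on the shared core would do.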